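This account rests on a few compounds, and the source may have more. Where it says the series, first, only, none or still open, it means among the compounds named here.

Among the measured compounds shown here, in a functional assay on MCF7 cells (Homo sapiens) for antiproliferative activity, read by MTT assay, with a stated time of 48 h (a lower number here means a stronger inhibitor, a higher number a weaker inhibitor), compound 2 `COC/C1=C/C[C@](C)(CCC=C(C)C)/C=C/[C@@H](OC(=O)C=C(C)C)[C@](C)(O)/C=C/C1=O` gives 4130 nM, the lower of the two numbers so far, and compound 1 `COC/C1=C/C[C@](C)(CCC=C(C)C)/C=C/[C@@H](OC(=O)C=C(C)C)[C@](C)(OC)/C=C/C1=O` gives 16500 nM. Compound 3 `CCN(CC)C/C1=C/C[C@](C)(CCC=C(C)C)/C=C/[C@@H](OC(=O)C=C(C)C)[C@](C)(O)/C=C/C1=O` has diethylamino in place of methoxy on a saturated chain carbon bound to a double-bonded ring carbon. For the measured compounds named here, the only measured step, a 4.0-fold lower number from compound 1 to compound 2 (0.60 log units; beyond the scatter), puts hydrogen in place of methyl on an oxygen on a saturated carbon. It concerns a different group and offers no direct guide, so no clear direction can be drawn. The expected step, not clearly beyond the scatter, is a 1.0-fold lower number from compound 2 to compound 3 (0.01 log units; within the scatter). For compound 3 the estimated value is 4000 nM, with an expected range from 1200 nM to 14000 nM.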

Compound 3, half-maximal inhibitory concentration: 130 nM
Compound 3: middle estimate off by 31-fold (1.49 log units), on the high side; measured number outside the range, below it.
By their numbers in this assay, from the lowest: compound 3; then compound 2; then compound 1.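

In this assay, diethylamino in place of methoxy on a saturated chain carbon bound to a double-bonded ring carbon gives a 32-fold lower number from compound 2 to compound 3 (1.50 log units; beyond the scatter). Among the compounds shown here, the earlier pair differed only by a methyl on an oxygen on a saturated carbon, so this is the first sign that the number also responds strongly to the group at this other place. Nothing measured here explains the drop.

The compounds shown leave open whether the nitrogen or the carbons of diethylamino matter more. Dimethylamino, a smaller amine, or morpholine, a ring amine, would help separate the two.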